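The source may report more compounds than this note shows. Statements on the series, on what has been measured and on what is new or still open speak of the compounds shown alone.

Measured compounds in an assay on HEK293 cells for positive allosteric modulation of metabotropic glutamate receptor 3 (Rattus norvegicus), read by thallium flux, with a stated time of 2.5 min; a higher number here means that more compound is needed for the effect, a lower number that less compound is needed:
compound 1, `Cc1c(OCCCCOc2cccc(C(=O)O)c2)ccc(C(=O)CC2CCCC2)c1O`, 3400 nM
compound 2, `Cc1c(OCCCCOc2ccc(F)c(C(=O)O)c2)ccc(C(=O)CC(C)C)c1O`, 920 nM

Compound 2 stands with the lowest of the two numbers in this assay; compound 1 has the higher number, and the gap between them lies beyond the scatter. Among the compounds with values here, compound 1 and compound 2 differ in more than one place, so no single step between measured compounds is counted, and the two values show only that the pair differ.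

Compound 3, `Cc1c(OCCCCOc2ccc(F)c(C(=O)O)c2)ccc(C(=O)CC2CCCC2)c1O`, is not yet measured. It differs from compound 2 in one place: cyclopentyl in place of isopropyl on a saturated chain carbon bound to a carbonyl carbon. Within the data shown here, no measured pair shows this change on its own, so its size and direction are open. The expected step from compound 2 to compound 3 is a 1.6-fold higher number from compound 2 to compound 3 (0.21 log units; within the scatter), with a wide range either way. Compound 3 is expected to give about 1500 nM in this assay, between 500 nM and 4500 nM.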

Compound 3, half-maximal effective concentration: 2490 nM
Compound 3: middle estimate off by 1.7-fold (0.22 log units), on the low side; the range from low to high includes it.
By their numbers in this assay, from the lowest: compound 2; then compounds 3 and 1 (each within the scatter of the next).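

In this assay, within the data shown here, cyclopentyl in place of isopropyl on a saturated chain carbon bound to a carbonyl carbon gives a 2.7-fold higher number from compound 2 to compound 3 (0.43 log units; beyond the scatter) and so provides the first single-place reading at this position, with the smaller isopropyl group holding the lower number in this one pair. With cyclopentyl held constant, fluoro in place of hydrogen on an aromatic carbon gives a 1.4-fold lower number from compound 1 to compound 3 (0.14 log units; within the scatter) and so shows no change beyond the scatter in this pair. No measured evidence bears on the reason for either step.

The compounds shown leave open whether the isopropyl to cyclopentyl step holds on the core without fluoro, and whether fluoro stays without effect alongside isopropyl. They also leave open how a longer chain, such as n-butyl, or an amine at this position would read.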